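A few compounds are considered here, and "the series" means these few. Any claim that something is new, unique, unknown or untested is made for them only; others in the source may bear on it.

Three compounds share one core and differ in the aryl group on the carbonyl carbon. Compound 1 `COc1cc(-c2cc(/C=C/C(=O)c3ccc(Cl)c(Cl)c3)[nH]n2)cc(OC)c1OC` carries a 3,4-dichlorophenyl there; compound 2 `COc1ccc(-c2cc(/C=C/C(=O)c3ccc(N)cc3)[nH]n2)cc1OC` and compound 3 `COc1ccc(-c2cc(/C=C/C(=O)c3cc(OC)c(OC)c(OC)c3)[nH]n2)cc1OC` carry other aryl groups. In a functional assay on NCI-H322M cells (Homo sapiens) for cytotoxicity, read by sulforhodamine B assay, with a stated time of 48 h, tested at 0.01 uM (a higher number here means a weaker effect of the compound at the concentration tested, a lower number a stronger effect), compound 1 gives 89%, compound 2 gives 96% and compound 3 gives 93%. Compound 1 thus holds the lowest of the three numbers, but its gap to compound 3 and its gap to compound 2 both lie within the usual scatter, so the three are not told apart here.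

Compound 4 `COc1cc(-c2cc(/C=C/C(=O)c3ccc(F)c(F)c3)[nH]n2)cc(OC)c1OC` has not yet been measured. It differs from compound 1 by one change: 3,4-difluorophenyl in place of 3,4-dichlorophenyl on a carbonyl carbon. Going by the values given here, no measured pair shows this change, so nothing points to a step beyond the scatter in this assay in either direction. Because compound 1 gives 89%, compound 4 is expected to give 92%, with a range from 80% to 102%, which is a step estimated as a number 3 percentage points higher from compound 1 to compound 4 (within the scatter).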

Compound 4, a percentage reported as activity, at one concentration (the size of the read-out at that concentration, not a potency): 94%
Beside the measured number, compound 4's estimate is 2 percentage points below it; the measured number falls inside the stated range.
By their numbers in this assay, from the lowest: compounds 1, 3, 4 and 2 (each within the scatter of the next).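

Going by these compounds alone, replacing 3,4-dichlorophenyl with 3,4-difluorophenyl on the carbonyl carbon gives the only step that can be read at this position in this assay, with a number 5 percentage points higher from compound 1 to compound 4 (within the scatter) at the single concentration tested. The earlier compounds shown here offered no one-place comparison, whereas this pair shows that exchanging two chlorine atoms for two fluorine atoms on this aryl ring does not separate the compounds in this read-out. Nothing available bears on the reason for the size of this step.

From the compounds shown here alone, whether a group of another kind on this aryl ring, such as a carboxylic acid, a nitrile or an amide, would give a step beyond the scatter remains open. Also open, going by these compounds, is whether an unsubstituted phenyl would stand apart from compound 1 and compound 4.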